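This account rests on a few compounds, and the source may have more. Where it says the series, first, only, none or still open, it means among the compounds named here.

In a functional assay on PC-3 cells (Homo sapiens) for inhibition, with a stated time of 48 h, tested at 50 uM (a lower number here means less inhibition of growth, a higher number more inhibition of growth at the concentration tested), compound 2 (`COc1ccc(/C=C/[C@@](C)(/C=C/c2ccc(O)cc2)CCC=C(C)C)cc1`) gives 50%. Compound 1 (`COc1ccccc1/C=C/[C@@](C)(/C=C/c1ccc(O)cc1)CCC=C(C)C`) lies within the scatter of it at 46%, while compound 3 (`COc1ccc(/C=C/[C@@](C)(/C=C/c2ccc(O)cc2)CCC=C(C)C)cc1C=O`) gives a clearly smaller number, 34%. The piece now turns to compound 4 (`CC(C)=CCCC(C)(/C=C/c1ccc(O)cc1)/C=C/c1ccc(O)cc1`), which differs from compound 2 as follows: hydrogen in place of methyl on an oxygen on an aromatic ring. This places hydrogen in place of methyl on an oxygen on an aromatic ring.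

Among the compounds with values here, no measured step makes this exact change, so the evidence is indirect. With 4-methoxyphenyl in place of 2-methoxyphenyl, the data show a number 4 percentage points higher from compound 1 to compound 2 (within the scatter). With formyl in place of hydrogen on an aromatic carbon, they show a number 16 percentage points lower from compound 2 to compound 3 (beyond the scatter), a modest step from a different kind of change. Neither step tests the methyl on that oxygen, so no step beyond the scatter is expected in this assay. The expected step is a number 4 percentage points lower from compound 2 to compound 4 (within the scatter). Compound 4 is estimated at 46%, with an expected range from 31% to 61%.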

Compound 4, percent growth inhibition at one concentration: 32%
For compound 4 the middle estimate is 14 percentage points above the measured one; the measured number falls inside the stated range.
By their numbers in this assay, from the lowest: compounds 4 and 3 (each within the scatter of the next); then compounds 1 and 2 (each within the scatter of the next).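

Replacing methyl with hydrogen on an oxygen on an aromatic ring gives, in this assay, a number 18 percentage points lower from compound 2 to compound 4 (beyond the scatter) in the percent growth inhibition. Within the data shown here, the earlier exchange of 2-methoxyphenyl for 4-methoxyphenyl gave only a number 4 percentage points higher from compound 1 to compound 2 (within the scatter), so this is the first sign that the methyl on that oxygen itself matters to the number, while the place of the methoxy group did not show any such effect. Nothing measured here gives a reason for this fall.

The compounds shown leave open whether a longer chain on that oxygen, such as ethyl, would stay close to compound 2 or fall towards compound 4. They also leave open how an amine in place of that oxygen would compare with either.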